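The source may hold more compounds than are shown below. What is called first, only, known or untested is meant among the compounds shown, and "the series" means these compounds.

Compound 1 `COC1(Cc2ccccc2C)CCN(c2ccc(C(=O)NS(=O)(=O)c3ccc(N[C@H](CCN(C)C)CSc4ccccc4)c([N+](=O)[O-])c3)cc2)CC1`, compound 2 `COC1(Cc2ccccc2-c2ccccc2)CCN(c2ccc(C(=O)NS(=O)(=O)c3ccc(N[C@H](CCN(C)C)CSc4ccccc4)c([N+](=O)[O-])c3)cc2)CC1` and compound 3 `CN(C)CC[C@H](CSc1ccccc1)Nc1ccc(S(=O)(=O)NC(=O)c2ccc(N3CCC(=Cc4ccccc4Cl)CC3)cc2)cc1[N+](=O)[O-]` share one core and differ only at the outer end of the molecule. In a functional assay (FL5.12 cells, Mus musculus) with Apoptosis regulator Bcl-2 (Homo sapiens) as the target (a lower number here means that less compound is needed, a higher number that more compound is needed for the effect), compound 1 gives 200 nM, compound 2 gives 20 nM, and compound 3 gives 450 nM. Compound 3 therefore stands highest of the three numbers, with compound 1 nearest to it and compound 2 furthest away, both of them beyond the scatter. For the measured compounds named here, the only step between measured compounds that differ in a single place is a 10-fold lower number from compound 1 to compound 2 (1.00 log units; beyond the scatter), where a methyl gave way to a phenyl on an aromatic carbon.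

Compound 4 `CN(C)CC[C@H](CSc1ccccc1)Nc1ccc(S(=O)(=O)NC(=O)c2ccc(N3CCC(=Cc4ccccc4C#N)CC3)cc2)cc1[N+](=O)[O-]` has not yet been measured. It differs from compound 3 by cyano in place of chloro on an aromatic carbon. Going by the values given here, none of the measured steps bears directly on this change: the one step that exists exchanges a small group for a much larger one, whereas here one small group gives way to another. With nothing in the data to point in either direction, compound 4 is expected to stay close to compound 3, a step of a 1.1-fold lower number from compound 3 to compound 4 (0.05 log units; within the scatter) that would not exceed the scatter. Compound 4 is accordingly estimated at 400 nM in this assay, within a range from 150 nM to 1100 nM.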

Compound 4, half-maximal effective concentration: 1600 nM
Beside the measured number, compound 4's estimate is 4.0-fold (0.60 log units) below it; measured number outside the range, above it.
By their numbers in this assay, from the lowest: compound 2; then compound 1; then compound 3; then compound 4.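

On the aromatic carbon ortho to a large group, the exchange of chloro for cyano is not a neutral swap: in this assay it gives a 3.6-fold higher number from compound 3 to compound 4 (0.55 log units; beyond the scatter), a change that lies beyond the scatter. For the compounds shown here, the only earlier step, a 10-fold lower number from compound 1 to compound 2 (1.00 log units; beyond the scatter), showed a falling number when phenyl replaced methyl, so this new step adds a rise in the number, and it shows that an exchange between two small groups on an aromatic carbon can also move the result beyond the scatter. No measurement is available that explains this rise.

On these data alone, whether the rise is tied to the cyano group itself or to the loss of the chloro remains open, and a fluoro, a methoxy, an amine or a carboxylic acid on the same carbon would help to separate these two readings. As far as these compounds go, it is equally open whether a phenyl at this carbon would lower the number of compound 3 and compound 4 as it did for the pair of compound 1 and compound 2.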